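This account rests on a few compounds, and the source may have more. Where it says the series, first, only, none or still open, it means among the compounds named here.

Three compounds have been measured in a functional assay on MDA-MB-231 cells (Homo sapiens) for inhibition, read by MTT assay, with a stated time of 48 h; a lower number here means a stronger inhibitor, a higher number a weaker inhibitor:

Compound 1 `COc1cc(/C=C/c2ccc(NC(=O)/C=C/c3ccc(C(F)(F)F)cc3)cc2)cc(OC)c1` gives 3520 nM.
Compound 2 `COc1cc(/C=C/c2ccc(NC(=O)/C=C/c3ccc(C#N)cc3)cc2)cc(OC)c1` gives 7740 nM.
Compound 3 `COc1cc(/C=C/c2ccc(NC(=O)/C=C/c3ccc([N+](=O)[O-])cc3)cc2)cc(OC)c1` gives 11700 nM.

Compound 1 has the lowest number of the three. The steps away from it, a 2.2-fold higher number from compound 1 to compound 2 (0.34 log units; beyond the scatter) and a 3.3-fold higher number from compound 1 to compound 3 (0.52 log units; beyond the scatter), are both beyond the scatter and modest in size, whereas a 1.5-fold higher number from compound 2 to compound 3 (0.18 log units; within the scatter) stays within the scatter. Compound 4 `COc1cc(/C=C/c2ccc(NC(=O)/C=C/c3ccc(Cl)cc3)cc2)cc(OC)c1` differs from compound 1 by chloro in place of trifluoromethyl on an aromatic carbon. Among the measured compounds shown here, no measured step puts chloro in at this carbon, so the two steps from compound 1 bear on it only loosely: each replacement of the trifluoromethyl gave a higher number, and a similar or smaller shift is expected here. Compound 4 is expected to give 4500 nM, within a range from 2000 nM to 10000 nM. This amounts to an expected step of a 1.3-fold higher number from compound 1 to compound 4 (0.11 log units; within the scatter).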

Compound 4, half-maximal inhibitory concentration: 14100 nM
Estimate against measurement, compound 4: 3.1-fold (0.50 log units) below; the whole stated range lies below it.
By their numbers in this assay, from the lowest: compound 1; then compounds 2, 3 and 4 (each within the scatter of the next).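

In this assay, chloro at this carbon also gives a higher number than trifluoromethyl (a 4.0-fold higher number from compound 1 to compound 4 (0.60 log units; beyond the scatter)), so all three replacements, including one of a single heavy atom for four, leave compound 1 with the lowest number. Chloro is not separated from nitro (a 1.2-fold higher number from compound 3 to compound 4 (0.08 log units; within the scatter)) or from cyano (a 1.8-fold higher number from compound 2 to compound 4 (0.26 log units; within the scatter)). No evidence here accounts for trifluoromethyl standing apart. On these data alone, whether any other group can match trifluoromethyl at this carbon stays open. A methyl, a methoxy, an amine or a carboxylic acid could match it or join the other three.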